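The source may hold more compounds than are shown below. What is called first, only, known or untested is meant among the compounds shown, and "the series" means these compounds.

In a physicochemical assay for solubility, in phosphate buffer, measured as kinetic solubility, at pH 7.4 (a higher number here means a more soluble compound, a lower number a less soluble compound), compound 1 `Cc1ccc(C)c(-c2nc(CN3CCC(C(=O)NCCCN4C[C@H](C)C[C@H](C)C4)CC3)c(C)o2)c1` gives 56.1 ug/mL and compound 2 `Cc1oc(-c2c(Br)cccc2Br)nc1CN1CCC(C(=O)NCCCN2C[C@H](C)C[C@H](C)C2)CC1` gives 62.4 ug/mL, two values within the scatter of each other. Compound 3 `Cc1oc(-c2c(Cl)cccc2C(F)(F)F)nc1CN1CCC(C(=O)NCCCN2C[C@H](C)C[C@H](C)C2)CC1` has 2-chloro-6-(trifluoromethyl)phenyl in place of 2,6-dibromophenyl on an aromatic carbon. For the measured compounds named here, the one measured step that bears on this change sits at the same place and is small: a 1.1-fold higher number from compound 1 to compound 2 (0.05 log units; within the scatter). No shift beyond the scatter is therefore expected in this assay, and the estimated step is a 1.1-fold lower number from compound 2 to compound 3 (0.05 log units; within the scatter). The estimate for compound 3 is 55 ug/mL, with an expected range from 25 ug/mL to 110 ug/mL.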

Compound 3, solubility: 65.1 ug/mL
Beside the measured number, compound 3's estimate is 1.2-fold (0.07 log units) below it; the measured number falls inside the stated range.
By their numbers in this assay, from the lowest: compounds 1, 2 and 3 (each within the scatter of the next).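

In this assay, the swap of 2,6-dibromophenyl for 2-chloro-6-(trifluoromethyl)phenyl gives a 1.0-fold higher number from compound 2 to compound 3 (0.02 log units; within the scatter) and the swap of 2,5-dimethylphenyl for the same group gives a 1.2-fold higher number from compound 1 to compound 3 (0.06 log units; within the scatter), so all three groups on this aromatic carbon read alike within the scatter. The halogen-only, alkyl-only and mixed trifluoromethyl groups thus stand level here. Nothing at hand accounts for this result. On these data alone, whether an amine or a carboxylic acid on this phenyl ring would keep the number in the same range stays open. As far as these compounds go, the effect of a longer chain elsewhere on the shared core also stays open.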